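From 4-nitrophenyl to 3-nitrophenyl on compound 3

The source may report more compounds than this note shows. Statements on the series, on what has been measured and on what is new or still open speak of the compounds shown alone.

Working notes on three measured compounds, each with a distinct structure. In a functional assay on RS4-11 cells (Homo sapiens) for inhibition, read by CCK-8 assay, with a stated time of 48 h (on this read-out higher numbers stand for weaker inhibition and lower numbers for stronger inhibition), compound 1 `COc1ccc(Oc2ccc(C(C)C)cc2-c2ccsc2S(=O)(=O)NCCNC(=S)Nc2ccc([N+](=O)[O-])cc2)cc1OC` gives 5800 nM. In the same read-out, compound 2 `O=[N+]([O-])c1ccc(NC(=S)NCCNS(=O)(=O)c2ccc(-c3ccccc3O[C@H]3CC[C@@H](O)CC3)s2)cc1` gives 9400 nM. Compound 3 `Cc1ccc(-c2ccsc2S(=O)(=O)NCCNC(=O)Nc2ccc([N+](=O)[O-])cc2)c(Oc2ccc(O)c(O)c2)c1` gives 7700 nM, which places it within the usual scatter of both other compounds, so no order can be drawn among them from these numbers.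

The next compound to be tested is compound 4 `Cc1ccc(-c2ccsc2S(=O)(=O)NCCNC(=O)Nc2cccc([N+](=O)[O-])c2)c(Oc2ccc(O)c(O)c2)c1`. It has the same atoms as compound 3, joined differently: 3-nitrophenyl in place of 4-nitrophenyl on an amide-type nitrogen. In words, 3-nitrophenyl stands in place of 4-nitrophenyl on an amide-type nitrogen.

For the measured compounds named here, no pair of measured compounds differs in only one place, so the data give no direct measure of what a single change does in this assay. No step beyond the scatter is expected, and no direction is favoured. The expectation starts from compound 3 at 7700 nM, and the range is kept wide to reflect the lack of a measured step. The estimated change is a 1.0-fold lower number from compound 3 to compound 4 (0.01 log units; within the scatter), which is expected to stay within the scatter. For compound 4 the estimated value is 7500 nM, with an expected range of 3500 nM to 15000 nM.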

Compound 4, half-maximal inhibitory concentration: 9100 nM
Compound 4: the middle estimate sits 1.2-fold (0.08 log units) below what was measured; measured number inside the range.
By their numbers in this assay, from the lowest: compounds 1, 3, 4 and 2 (each within the scatter of the next).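

In this assay, for the compounds shown here, 3-nitrophenyl in place of 4-nitrophenyl on an amide-type nitrogen gives a 1.2-fold higher number from compound 3 to compound 4 (0.07 log units; within the scatter), the first step between compounds that differ in one place only. With the rest of the structure and the atom count held constant, the two nitrophenyl isomers cannot be told apart in this read-out, so this change on this nitrogen gives no measurable handle on the number, at least on the core shared by compound 3 and compound 4. No measurement bearing on this result is available, and the step is recorded without any explanation.

On these data alone, it remains open whether a different group on this phenyl ring, such as an amine or a carboxylic acid in place of the nitro group, would produce a step beyond the scatter. As far as these compounds go, it is also open whether the same exchange of 4-nitrophenyl for 3-nitrophenyl would stay within the scatter on compounds with a thiocarbonyl in place of the carbonyl, as in the cores of compound 1 and compound 2.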